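The source may report more compounds than this note shows. Statements on the series, on what has been measured and on what is new or still open speak of the compounds shown alone.

Compound 1 `C=C1C[C@]23C[C@@]1(O)CC[C@H]2c1ccc(O)c(C)c1[C@@H]3Cn1cc(-c2ccccn2)nn1` is the starting point. In a functional assay on SW480 cells (Homo sapiens) for cytotoxicity, read by MTT assay, with a stated time of 4 days (on this read-out higher numbers stand for weaker inhibition and lower numbers for stronger inhibition), compound 1 gives only a limit, > 20000 nM. Compound 2 `C=C1C[C@]23C[C@@]1(O)CC[C@H]2c1cc(Br)c(O)c(C)c1[C@@H]3Cn1cc(-c2ccccn2)nn1`, with bromo in place of hydrogen on an aromatic carbon, likewise gives only a limit, > 20000 nM. Compound 3 `C=C1C(=O)[C@]23C[C@@]1(O)CC[C@H]2c1ccc(OS(=O)(=O)c2ccc(C)cc2)c(C)c1[C@@H]3Cn1cc(-c2ccc(C)cc2)nn1` gives 1460 nM. Two of the three values thus rest on (the limit of > 20000 nM in this assay, at which 2 of the 3 values shown sit), and the step that the two limits leave unreadable from compound 1 to compound 2 cannot be sized. Compound 4 `C=C1C[C@]23C[C@@]1(O)CC[C@H]2c1ccc(O)c(C)c1[C@@H]3Cn1cc(-c2ccc(F)cc2)nn1` differs from compound 1 by 4-fluorophenyl in place of pyridin-2-yl on an aromatic carbon. Going by the values given here, no measured step changes the group on the five-membered aromatic ring with 3 nitrogen on its own, so no step beyond the scatter is expected for a number no higher from compound 1 to compound 4 (the limit leaves the size open), and compound 4 is expected to stay close to the limit. The estimate for compound 4 is 20000 nM, with a range from 5000 nM to 60000 nM.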

Compound 4, half-maximal inhibitory concentration: > 20000 nM
Compound 4: no number, only a limit; the forecaster's own chance of this, stated with the estimate: 60%; the middle value lies on the limit itself.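

In this assay, going by these compounds alone, compound 1 and compound 4 each give only a limit, so no step between them can be read. The compounds shown leave open whether 4-fluorophenyl in place of pyridin-2-yl changes the read-out at all.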